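The compounds below may be only part of what the source reports. "The series", "measured", "known", "first", "only" and "open" are said of these compounds alone.

Measured in a functional assay on HCT-116 cells (Homo sapiens) for cytotoxicity, read by sulforhodamine B assay, with a stated time of 24 h; on this read-out higher numbers stand for weaker inhibition and lower numbers for stronger inhibition:
- compound 1 `N=c1oc2ccccc2cc1C(=O)N/N=C1\C(=O)Nc2ccc(S(=O)(=O)N3CCOCC3)cc21`: 6750 nM
- compound 2 `O=C1Nc2ccc(S(=O)(=O)N3CCOCC3)cc2/C1=N/c1ccc(Br)cc1`: 15300 nM
- compound 3 `N/N=C1\C(=O)Nc2ccc(S(=O)(=O)N3CCOCC3)cc21`: 36300 nM

Of these three, compound 3 has the highest number, which makes it the weakest inhibitor of the set. Compound 2 lies nearest to it, and compound 1 lies furthest below it.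

Compound 4 `O=C1Nc2ccc(S(=O)(=O)N3CCOCC3)cc2/C1=N/NC(=O)c1ccccc1` has not yet been measured. It arises from compound 3 with benzoyl in place of hydrogen on an amine nitrogen.

For the measured compounds named here, only one measured step bears directly on this change: a 2.4-fold higher number from compound 2 to compound 3 (0.38 log units; beyond the scatter). This modest step replaces 4-bromophenyl with amino on a double-bonded nitrogen, so it shows the compound carrying the aromatic group with the lower number. Going by the values given here, compound 1, at 6750 nM, also gives a lower number than compound 3, although no single-change step links them. A modest step towards a lower number is therefore expected in this assay, but this rests on very few compounds. The expected change is a 2.6-fold lower number from compound 3 to compound 4 (0.41 log units; beyond the scatter). For compound 4 the estimate is 14000 nM, with an expected range of 6000 nM to 30000 nM.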

Compound 4, half-maximal inhibitory concentration: 28900 nM
Beside the measured number, compound 4's estimate is 2.1-fold (0.31 log units) below it; measured number inside the range.
By their numbers in this assay, from the lowest: compound 1; then compounds 2, 4 and 3 (each within the scatter of the next, the first and the last beyond it).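

Placing benzoyl on the amine nitrogen of compound 3 adds an aromatic ring, yet the outcome is a 1.3-fold lower number from compound 3 to compound 4 (0.10 log units; within the scatter), so in this assay this position does not distinguish benzoyl from hydrogen. The comparison with the 4-bromophenyl compound gives a 1.9-fold higher number from compound 2 to compound 4 (0.28 log units; within the scatter), so benzamido and 4-bromophenyl on the double-bonded nitrogen also cannot be told apart here. A separation appears only at the carbonyl carbon, with a 4.3-fold higher number from compound 1 to compound 4 (0.63 log units; beyond the scatter), which shows that the group of compound 1 with its two six-membered rings counts for more in this series than a simple phenyl ring there.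

Going by these compounds, whether an acetyl group or a pyridine-3-carbonyl group on the amine nitrogen would behave as benzoyl does remains open. Nothing given here offers an explanation for these numbers.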